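Replacing the aryl group on a growth inhibitor

The compounds below may be only part of what the source reports. "The series", "measured", "known", "first", "only" and "open" are said of these compounds alone.

Measured values:
compound 1 `COc1cc(/C=C/C(=O)c2cccc(-n3cc(-c4ccc(Cl)cc4)[nH]c3=O)c2)cc(OC)c1OC` in a functional assay on HT-29 cells (Homo sapiens) for inhibition (on this read-out lower numbers stand for stronger inhibition of growth and higher numbers for weaker inhibition of growth), gives 2000 nM
compound 2 `COc1cc(/C=C/C(=O)c2cccc(-n3cc(-c4ccccc4)[nH]c3=O)c2)ccc1O` in this assay gives 3770 nM

In this assay compound 1 stands level with compound 2, since their two values lie within the scatter of each other. The next compound, compound 3 `COc1cc(/C=C/C(=O)c2cccc(-n3cc(-c4cc(OC)c(OC)c(OC)c4)[nH]c3=O)c2)cc(OC)c1OC`, keeps the core of compound 1 and carries 3,4,5-trimethoxyphenyl in place of 4-chlorophenyl on an aromatic carbon. For the measured compounds named here, no measured pair differs in one place only, and the data hold no direct guide to this change. Taking compound 1 at 2000 nM as the starting point, no step beyond the scatter is expected in this assay, and neither direction is favoured. The estimated step (a 1.1-fold lower number from compound 1 to compound 3 (0.05 log units; within the scatter)) is correspondingly small. Compound 3 is expected at 1800 nM (estimated range 500 nM to 6000 nM).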

Compound 3, concentration for 50% growth inhibition: 1700 nM
Compound 3: middle estimate off by 1.1-fold (0.02 log units), on the high side, within the range that was stated.
By their numbers in this assay, from the lowest: compounds 3, 1 and 2 (each within the scatter of the next, the first and the last beyond it).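

In this assay, for the compounds shown here, putting 3,4,5-trimethoxyphenyl in place of 4-chlorophenyl on an aromatic carbon of a five-membered aromatic ring with 2 nitrogen gives a 1.2-fold lower number from compound 1 to compound 3 (0.07 log units; within the scatter), the first step in this set between compounds that differ in one place. It shows that at this position the larger group, which brings three methoxy groups and hydrogen-bond acceptors where 4-chlorophenyl has none, leaves the growth read-out within the scatter. Nothing on hand explains why the two groups read alike. Still open, from the compounds shown here alone, is how an amine or a carboxylic acid on the aryl group, or a plain methyl group in its place, would read in this assay on the core of compound 1. Also open, going by these compounds, is whether this exchange would read the same way on another cell line.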